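Swapping Chloro for Fluoro on Two Related Cores

The source may report more compounds than this note shows. Statements on the series, on what has been measured and on what is new or still open speak of the compounds shown alone.

Of the compounds shown here, three have so far been measured in an assay on isolated protein for binding affinity to 5-hydroxytryptamine receptor 6 (Homo sapiens); on this read-out higher numbers stand for weaker inhibition and lower numbers for stronger inhibition. Compound 1 `Clc1ccc(-c2n[nH]cc2N2CCCNCC2)cc1` gives 1090 nM. Compound 2 `Fc1ccc(-c2n[nH]cc2N2CCCNCC2)cc1` differs from compound 1 in a single spot, (fluoro in place of chloro on an aromatic carbon), and in this assay compound 2 gives 2290 nM. That single swap produced a 2.1-fold higher number from compound 1 to compound 2 (0.32 log units; beyond the scatter). Compound 3 `Clc1ccc(-c2n[nH]cc2N2CCNCC2)cc1` keeps the same chloro-bearing aromatic ring but sits on a different core; the difference between the two cores is not broken down here. In this assay compound 3 gives 75 nM, the lowest number of the three, and its gaps to compound 1 and to compound 2 both lie beyond the usual scatter.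

Compound 4 `Fc1ccc(-c2n[nH]cc2N2CCNCC2)cc1` has not yet been measured. It stands to compound 3 as compound 2 stands to compound 1: the change is fluoro in place of chloro on an aromatic carbon, the same change at the same place on the aromatic ring. The earlier swap was modest, and a step of similar size is expected here. Compound 4 is therefore expected to show a 2.0-fold higher number from compound 3 to compound 4 (0.30 log units; within the scatter). This expectation rests on the measured step of a 2.1-fold higher number from compound 1 to compound 2 (0.32 log units; beyond the scatter). The resulting estimate for compound 4 is 150 nM, with a likely range from 60 nM to 400 nM.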

Compound 4, inhibition constant: 373 nM
For compound 4 the middle estimate is 2.5-fold (0.40 log units) below the measured one, within the range that was stated.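

Fluoro in place of chloro on the aromatic carbon now has two readings in this assay, and both point the same way, towards weaker binding: the new step is a 5.0-fold higher number from compound 3 to compound 4 (0.70 log units; beyond the scatter) and it joins the earlier step of a 2.1-fold higher number from compound 1 to compound 2 (0.32 log units; beyond the scatter) on the other core. The two steps can be treated as one effect of similar size, since the gap between them is no larger than repeated measurements would give: the same change on two cores in this assay, a 2.1-fold higher number (0.32 log units; beyond the scatter) from compound 1 to compound 2 and a 5.0-fold higher number (0.70 log units; beyond the scatter) from compound 3 to compound 4, 2.4-fold (0.37 log units) apart, within the scatter of two such steps.

So in this small series, the swap carried over from one core to the other in direction, and the larger number on the newer pair should not be read as a real difference in size; two cores are also too few to show that the step would hold on any further core.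

Going by these compounds, what remains open is how other groups would behave in the same place on the aromatic ring, para to a large group. A bromo or a methoxy group, for example, could be set beside chloro and fluoro on both cores to show how far this trend extends.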